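The source may hold more compounds than are shown below. What is called first, only, known or untested is meant among the compounds shown, and "the series" means these compounds.

In an ADME assay on microsomes from liver (Homo sapiens) for metabolic stability, read by LC-MS, with a stated time of 30 min, tested at 1 uM (a lower number here means that less of the compound is left, a higher number that more of the compound is left), compound 1 `O=C(NCc1ccc(S(=O)(=O)c2ccccc2)cc1)c1nc2cnccc2[nH]1` gives 73% and compound 2 `Cn1c(C(=O)NCc2ccc(S(=O)(=O)c3ccccc3)cc2)cc2ccncc21` gives 71%. These two values lie within the scatter of each other, so compound 1 stands level with compound 2 on the numbers available. Compound 3 `O=C(NCc1ccc(S(=O)(=O)c2ccccc2)cc1)c1cn2ccnc2cn1`, not yet measured, differs from compound 1 by a group of 9 heavy atoms (6 carbon, 3 nitrogen; one five-membered aromatic ring with 2 hetero atoms, one six-membered aromatic ring with 2 hetero atoms) in place of a group of 9 heavy atoms (6 carbon, 3 nitrogen; one five-membered aromatic ring with 2 hetero atoms, one six-membered aromatic ring with 1 hetero atom), on a carbonyl carbon. The two have the same atoms, joined differently. Within the data shown here, no measured pair gives a size for a change of this kind, so the expectation is anchored on compound 1 at 73% and kept wide. The estimated step of a number 7 percentage points lower from compound 1 to compound 3 (within the scatter) is expected to be small and slightly downward, not beyond the scatter. For compound 3 the expected value is 66%, with an estimated range of 45% to 84%.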

Compound 3, percent of the compound remaining: 87%
Compound 3: middle estimate off by 21 percentage points, on the low side; measured number above the stated range.
By their numbers in this assay, from the lowest: compounds 2 and 1 (each within the scatter of the next); then compound 3.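

In this assay the group on the carbonyl carbon matters even when its atoms stay the same and are only joined differently: the read-out moves a number 14 percentage points higher from compound 1 to compound 3 (beyond the scatter). Among these compounds, this is the first step that lies beyond the scatter, so this position can respond to a rearrangement alone. The change goes from 1 hydrogen-bond donor and 2 hydrogen-bond acceptors in the group that leaves to 0 hydrogen-bond donors and 3 hydrogen-bond acceptors in the group that enters, but no measurement bears on why the number moved.

With a single step, the donor count and the arrangement of the ring atoms cannot be told apart. From the compounds shown here alone, it also remains open how the read-out responds if an amine or a carboxylic acid is attached to the group that enters.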